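Replacing the Amide Aryl Group in a Catechol Ether Amide

The source may report more compounds than this note shows. Statements on the series, on what has been measured and on what is new or still open speak of the compounds shown alone.

Of the compounds shown here, three built on a shared core have been measured in an assay on isolated protein for inhibition of phosphodiesterase 4A (Sus scrofa); on this read-out lower numbers stand for stronger inhibition and higher numbers for weaker inhibition. Going by the values given here, compound 1, `COc1ccc(C(=O)Nc2ccccc2F)cc1OC1CCCC1`, carries a 2-fluorophenyl group on its amide nitrogen and gives 10700 nM, the highest of the two numbers known. Compound 3, `COc1ccc(C(=O)Nc2c(F)c(F)nc(F)c2F)cc1OC1CCCC1`, gives 550 nM, a clearly lower number, beyond the usual scatter. Compound 2, `COc1ccc(C(=O)Oc2c(Cl)cccc2Cl)cc1OC1CCCC1`, an ester rather than an amide, returned only a limit in this assay, > 1000000 nM, so no number is known for it; the evidence here is simply (the limit of > 1000000 nM in this assay, at which 1 of the 3 values shown sits).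

Compound 4, `COc1ccc(C(=O)NN2C(Cl)=NC=CC2Cl)cc1OC1CCCC1`, has not yet been measured. Compared with compound 1, the change is a group of 8 heavy atoms (4 carbon, 2 nitrogen, 2 chlorine; one six-membered non-aromatic ring with 2 hetero atoms) in place of a group of 7 heavy atoms (6 carbon, 1 fluorine; one six-membered aromatic ring of carbon only), on an amide-type nitrogen.

Among the compounds with values here, no measured pair differs in exactly one place, so the size of this step can only be expected, not read off. On these data alone, since compound 3 gives 550 nM with a halogen-rich nitrogen-containing ring in place of the fluorophenyl group, a lower number than compound 1 seems more likely than a higher one, though the attachment through a ring nitrogen is untested here. The expected step is a 3.6-fold lower number from compound 1 to compound 4 (0.55 log units; beyond the scatter), a modest improvement beyond the scatter. Compound 4 is estimated at 3000 nM, with a range from 300 nM to 30000 nM.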

Compound 4, half-maximal inhibitory concentration: 400 nM
Beside the measured number, compound 4's estimate is 7.5-fold (0.88 log units) above it; the range from low to high includes it.
By their numbers in this assay, from the lowest: compounds 4 and 3 (each within the scatter of the next); then compound 1. At a limit, above all of these: compound 2.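

Changing the group on this amide-type nitrogen can strongly affect the result: in this assay, replacing the 2-fluorophenyl group with the chlorine-bearing, non-aromatic ring gives a 27-fold lower number from compound 1 to compound 4 (1.43 log units; beyond the scatter), a large step. The position therefore accepts a non-aromatic ring with two hetero atoms, attached through a ring nitrogen, and does not depend on an aromatic ring of carbon only. Compound 3 gives 550 nM and compound 4 gives 400 nM, values within the scatter of each other, so two differently built rings carrying halogens and nitrogen reach the same level on this read-out, while nothing measured here explains why the step from the 2-fluorophenyl compound is so large.

The change swaps the ring type, the halogen and the ring atoms all at once, so the compounds shown cannot say which of these differences accounts for the step. A plain phenyl group, a cyclohexyl group or the same non-aromatic ring without its chlorine atoms would help separate these contributions.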